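Shortening the link to the five-membered ring, compound 4

The source may report more compounds than this note shows. Statements on the series, on what has been measured and on what is new or still open speak of the compounds shown alone.

Three compounds of the series have numbers in a functional assay on CHO cells for antagonist activity at prostaglandin E2 receptor EP3 subtype (Homo sapiens), read by cAMP accumulation; a lower number here means a stronger inhibitor, a higher number a weaker inhibitor. Compound 1 `CC(C)C(Nc1nnc[nH]1)c1ccc(-c2ccc3cccc(F)c3c2)[nH]c1=O` gives 185 nM, compound 2 `CC(C)C(Cc1nnc[nH]1)c1ccc(-c2ccc3cccc(F)c3c2)[nH]c1=O` gives 17 nM, and compound 3 `CC(C)C(Cc1noc(=O)[nH]1)c1ccc(-c2ccc3cccc(F)c3c2)[nH]c1=O` gives 70 nM. Compound 3 therefore stands second highest of the three, nearer to compound 1 than to compound 2; the measured steps are a 2.6-fold lower number from compound 1 to compound 3 (0.42 log units; beyond the scatter) and a 4.1-fold higher number from compound 2 to compound 3 (0.61 log units; beyond the scatter).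

Compound 4 `CC(C)C(c1noc(=O)[nH]1)c1ccc(-c2ccc3cccc(F)c3c2)[nH]c1=O` differs from compound 3 by a group of 6 heavy atoms (2 carbon, 2 nitrogen, 2 oxygen; one five-membered aromatic ring with 3 hetero atoms) in place of a group of 7 heavy atoms (3 carbon, 2 nitrogen, 2 oxygen; one five-membered aromatic ring with 3 hetero atoms), on a saturated chain carbon bound to an aromatic carbon and a saturated chain carbon: the five-membered ring is now bound directly to the chain carbon, with no single-atom link in between.

Among the measured compounds shown here, only one measured step concerns the link at that carbon, an 11-fold lower number from compound 1 to compound 2 (1.04 log units; beyond the scatter), where one single-atom link replaced another. For the measured compounds named here, no measured pair removes the link altogether, and both ring swaps, a 2.6-fold lower number from compound 1 to compound 3 (0.42 log units; beyond the scatter) and a 4.1-fold higher number from compound 2 to compound 3 (0.61 log units; beyond the scatter), keep the link in place. The direction of a step in this assay on removing the link is thus not fixed by the data; given that the link has mattered strongly once, a step beyond the scatter in either direction is possible, and a modest loss is taken as the middle expectation. The expected step is a 2.1-fold higher number from compound 3 to compound 4 (0.33 log units; beyond the scatter). Compound 4 is estimated at 150 nM, with a range from 40 nM to 600 nM.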

Compound 4, half-maximal inhibitory concentration: 41 nM
For compound 4 the middle estimate is 3.7-fold (0.56 log units) above the measured one; low and high end bracket the measured number.
By their numbers in this assay, from the lowest: compound 2; then compounds 4 and 3 (each within the scatter of the next); then compound 1.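

At the saturated chain carbon bound to an aromatic carbon and a saturated chain carbon, the link is not needed to hold the level of the oxadiazolone-type ring in this assay, since the two compounds cannot be told apart: a 1.7-fold lower number from compound 3 to compound 4 (0.23 log units; within the scatter). Compound 2 keeps the lowest number of the series, with a 2.4-fold higher number from compound 2 to compound 4 (0.38 log units; beyond the scatter), and compound 4 remains clear of the amino-linked compound 1, with a 4.5-fold lower number from compound 1 to compound 4 (0.65 log units; beyond the scatter), though both of these steps change the ring and the link together, so neither can be assigned to one of the two alone. No further measurement is available that bears on this result.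

Among the compounds shown here, whether the link is equally dispensable for the 4H-1,2,4-triazol-3-yl ring remains open, as the single comparison with and without the link concerns only the ring of compound 3 and compound 4. Also open, going by these compounds, is how a carboxylic acid, a primary amine or a longer chain carrying the ring would fare on the same carbon.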